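This account rests on a few compounds, and the source may have more. Where it says the series, first, only, none or still open, it means among the compounds named here.

Going by the values given here, compound 3 `CC1(C)[C@H]2CC[C@]1(C)N(Cc1cn(-c3ccc(C#N)cc3)nn1)C(=O)C2` gives 380 nM in a functional assay on OVCAR-3 cells (Homo sapiens) for inhibition, read by MTT assay, with a stated time of 24 h (on this read-out lower numbers stand for stronger inhibition and higher numbers for weaker inhibition), the highest of the three numbers measured so far: compound 1 `CC1(C)[C@H]2CC[C@]1(C)N(Cc1cn(-c3ccccc3O)nn1)C(=O)C2` gives 90 nM and compound 2 `COc1ccc(-n2cc(CN3C(=O)C[C@@H]4CC[C@@]3(C)C4(C)C)nn2)cc1` gives 250 nM. The steps of a 4.2-fold higher number from compound 1 to compound 3 (0.63 log units; beyond the scatter) and a 1.5-fold higher number from compound 2 to compound 3 (0.18 log units; within the scatter) describe exchanges of the whole group on the aromatic nitrogen, and the second of them stays within the scatter. Compound 4 `CC1(C)[C@H]2CC[C@]1(C)N(Cc1cn(-c3cccc(C#N)c3)nn1)C(=O)C2` differs from compound 3 by 3-cyanophenyl in place of 4-cyanophenyl on an aromatic nitrogen. Among the compounds with values here, no measured step moves a cyano from one place on the ring to another, so nothing in these numbers argues for a shift beyond the scatter; the expected step is no change at the digits printed from compound 3 to compound 4 (within the scatter). Compound 4 is therefore estimated at 380 nM, with a range from 150 nM to 950 nM.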

Compound 4, half-maximal inhibitory concentration: 230 nM
The estimate for compound 4 lay 1.7-fold (0.22 log units) above the measured number; the measured number falls inside the stated range.
By their numbers in this assay, from the lowest: compound 1; then compounds 4, 2 and 3 (each within the scatter of the next).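

Moving the nitrile, with 3-cyanophenyl in place of 4-cyanophenyl, gives a 1.7-fold lower number from compound 3 to compound 4 (0.22 log units; within the scatter) in this assay and so stays within the scatter. Exchanging 4-methoxyphenyl for 3-cyanophenyl gives a 1.1-fold lower number from compound 2 to compound 4 (0.04 log units; within the scatter) and also stays within it, while the exchange of 2-hydroxyphenyl for 3-cyanophenyl gives a 2.6-fold higher number from compound 1 to compound 4 (0.41 log units; beyond the scatter) and lies beyond it. Nothing available here explains these steps. The compounds shown leave open how a carboxylic acid or an amine in place of the nitrile would read in this assay and whether the 2-hydroxyphenyl result depends on its hydroxyl.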